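This account rests on a few compounds, and the source may have more. Where it says the series, first, only, none or still open, it means among the compounds named here.

For the measured compounds named here, compound 1 `Cc1cc(C)c(Oc2cc(Nc3ccc(C#N)cc3)ncc2C(=O)NCc2cn(CC(N)=O)nn2)c(C)c1` is the only member of the series with a numerical value in an ADME assay on MT4 cells (Homo sapiens) for cytotoxicity, read by MTT assay, with a stated time of 5 days (a lower number here means that less compound is tolerated, a higher number that more compound is tolerated), where compound 1 gives 24000 nM. Compound 2 `Cc1cc(C)c(Oc2cc(Nc3ccc(C#N)cc3)ncc2C(=O)NCc2cn(Cc3ccc(Cl)cc3)nn2)c(C)c1` reaches only a limit, >= 120000 nM. Going by the values given here, the step of an at least 5.0-fold higher number from compound 1 to compound 2 (0.69 log units; beyond the scatter) is the one measured change at this position, and it sits at the limit of >= 120000 nM in this assay, at which 1 of the 2 values shown sits.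

Compound 3 `Cc1cc(C)c(Oc2cc(Nc3ccc(C#N)cc3)ncc2C(=O)NCc2cn(Cc3ccc([N+](=O)[O-])cc3)nn2)c(C)c1` follows the same direction: 4-nitrophenyl in place of carbamoyl on a saturated chain carbon bound to an aromatic nitrogen. With a 4-chlorophenyl having moved the number beyond the scatter, a 4-nitrophenyl at the same saturated chain carbon is expected to give a step of similar size in this assay, a 3.8-fold higher number from compound 1 to compound 3 (0.57 log units; beyond the scatter), so compound 3 is estimated at 90000 nM, between 30000 nM and 200000 nM.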

Compound 3, half-maximal cytotoxic concentration: >= 139000 nM
Compound 3 ended at the assay's limit; the forecaster's own chance of this, stated with the estimate: 50%; middle value at least 1.5-fold (0.18 log units) from the limit.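

In this assay, the higher number at this saturated chain carbon is not tied to 4-chlorophenyl, since 4-nitrophenyl in place of carbamoyl also gives it: an at least 5.7-fold higher number from compound 1 to compound 3 (0.76 log units; beyond the scatter). Compound 3 gives a limit, not a number: the limit of >= 139000 nM in this assay, at which 1 of the 3 values shown sits. The step from nitro to chloro on the aromatic carbon cannot be read, so the two substituents stay unordered.

Open, going by these compounds, is whether an unsubstituted phenyl or a 4-methoxyphenyl at the same carbon also ends at a limit in this assay. Also open, on these data alone, is where a carboxylic acid or a longer chain carrying an amine would fall.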